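A few compounds are considered here, and "the series" means these few. Any claim that something is new, unique, unknown or untested is made for them only; others in the source may bear on it.

The shared core, the structure of compound 1 being `CCCC(Nc1cncc(-c2ccc(O)c(OC)c2)n1)c1ccccc1`, carries a phenyl on the saturated chain carbon bound to the ring nitrogen. In a functional assay on PC-3 cells (Homo sapiens) for cytotoxicity, read by MTT assay, with a stated time of 72 h (a lower number here means a stronger inhibitor, a higher number a weaker inhibitor), compound 1 gives 160 nM. Compound 2, `CCCC(Nc1cncc(-c2ccc(O)c(OC)c2)n1)c1ccc(OC)cc1`, differs from it by a methoxy in place of hydrogen on an aromatic carbon; in this assay compound 2 gives 3000 nM, and the change a 19-fold higher number from compound 1 to compound 2 (1.27 log units; beyond the scatter) is large and beyond the scatter. As far as these compounds go, compound 3, `CCCC(Nc1cncc(-c2ccc(O)c(OC)c2)n1)c1ccc(F)cc1`, stands without a number in this assay: in this assay compound 3 gives "not determined" (no result reported), so its own position is unknown. Compound 4, `CCCC(Nc1cncc(-c2ccc(O)c(OC)c2)n1)c1cccc(Cl)c1`, differs from compound 3 by 3-chlorophenyl in place of 4-fluorophenyl on a saturated chain carbon bound to a nitrogen on an aromatic ring and a saturated chain carbon. For the measured compounds named here, no measured step bears directly on this exchange; the only measured step, from compound 1 to compound 2, concerns a different substituent and shows that a change on this phenyl can move the number a great deal. For compound 4 the estimated value in this assay is 500 nM, expected to fall between 100 nM and 3000 nM.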

Compound 4, half-maximal inhibitory concentration: 1000 nM
Beside the measured number, compound 4's estimate is 2.0-fold (0.30 log units) below it; measured number inside the range.
By their numbers in this assay, from the lowest: compound 1; then compound 4; then compound 2.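

In this assay, the rise in the number on this phenyl is no longer tied to methoxy, since chloro in place of hydrogen also goes with a higher number, with a 6.3-fold higher number from compound 1 to compound 4 (0.80 log units; beyond the scatter). The two substituted phenyls also stand apart from each other, with a 3.0-fold lower number from compound 2 to compound 4 (0.48 log units; beyond the scatter), so the outcome at this place depends on which group is carried and where, and among compounds 1, 2 and 4 the plain phenyl of compound 1 keeps the lowest number. Nothing measured here explains these differences.

Compound 3 has no number, so the step from compound 3 to compound 4 cannot be read. 3-Chlorophenyl and 4-methoxyphenyl differ in both the group and its ring position, leaving open how a 4-chlorophenyl or a 3-methoxyphenyl would stand.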